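Chain end on the oxadiazolone nitrogen: from hydroxy to methyl ester

The source may hold more compounds than are shown below. What is called first, only, known or untested is meant among the compounds shown, and "the series" means these compounds.

Compound 1 `COc1ccc(F)cc1-c1cccc(-c2nn(CCCCF)c(=O)o2)c1` carries a 2-fluoroethyl chain end on the saturated chain two bonds along from the aromatic nitrogen; in a functional assay on the whole organism (strain Wistar albino) for inhibition, with Rattus norvegicus as the target, read by paw edema, with stated times of 30 min and 3 h, at a dose of 10 mg/kg by the oral route (a lower number here means less inhibition, a higher number more inhibition at the dose given (going by the name of the read-out)), compound 1 gives 95%. Within the data shown here, compound 2 `COc1ccc(F)cc1-c1cccc(-c2nn(CCO)c(=O)o2)c1` has hydroxy at that position and in this assay compound 2 gives 75%, the lowest of the two numbers measured so far, the only other compound being compound 1 with a higher number, the step of a number 20 percentage points lower from compound 1 to compound 2 (beyond the scatter).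

Compound 3 `COC(=O)CCCn1nc(-c2cccc(-c3cc(F)ccc3OC)c2)oc1=O` is not yet measured. The change from compound 2 is (methoxycarbonyl)methyl in place of hydroxy on a saturated chain carbon, two bonds along the chain from an aromatic nitrogen. Read one bond further out, it is 2-hydroxyethyl to 3-(methoxycarbonyl)propyl, a chain that grows again after it was shortened to hydroxy.

Among the measured compounds shown here, only one measured step bears on it: from compound 1 to compound 2 the loss of a longer chain end cost a number 20 percentage points lower from compound 1 to compound 2 (beyond the scatter). The return to a longer chain end, now carrying a methoxycarbonyl rather than fluorine, is expected to recover part of that. For compound 3 the estimated step is a number 10 percentage points higher from compound 2 to compound 3 (within the scatter) in this assay. For compound 3 the estimate is 85%, within 68% to 96%.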

Compound 3, a percentage reported as inhibition, in the whole organism at one dose (the size of the read-out at that dose, not a potency): 87%
Beside the measured number, compound 3's estimate is 2 percentage points below it; the measured number falls inside the stated range.
By their numbers in this assay, from the lowest: compound 2; then compounds 3 and 1 (each within the scatter of the next).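

In this assay, the position accepts a far larger chain end than hydroxy: a number 12 percentage points higher from compound 2 to compound 3 (beyond the scatter), with (methoxycarbonyl)methyl entering and its 5 heavy atoms, 0 hydrogen-bond donors and 2 hydrogen-bond acceptors replacing hydroxy. The two chain ends at the far end of the longer chains cannot be told apart at this dose: a number 8 percentage points lower from compound 1 to compound 3 (within the scatter), so methoxycarbonyl in place of fluoromethyl leaves no change that can be read, and compound 2, with steps beyond the scatter to both other compounds, alone stands lowest among these three. No measurement shown gives a reason for these differences.

Compound 2 differs from the others in both chain length and chain end, so the share of each remains unresolved, and a hydroxy group on a chain as long as that of compound 3 would be needed to separate them. Also open, on these data alone, is how this position responds to a carboxylic acid or an amine at the chain end, or to a longer chain, and with one dose the numbers say nothing about potency.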